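Extending the isopropyl ether to 1-methylbutyl

The source may report more compounds than this note shows. Statements on the series, on what has been measured and on what is new or still open speak of the compounds shown alone.

In a functional assay on LNCaP cells (Homo sapiens) for antiproliferative activity, read by WST assay, with a stated time of 3 days (on this read-out lower numbers stand for stronger inhibition and higher numbers for weaker inhibition), compound 3 `COc1cc(-c2oc3ccccc3c(=O)c2OC(C)C)cc(OC)c1OC` gives 8800 nM. Compound 1 `CCCCOc1c(-c2cc(OC)c(OC)c(OC)c2)oc2ccccc2c1=O` gives 8900 nM, so these two sit level within the scatter. Compound 2 `CCCCCCCOc1c(-c2cc(OC)c(OC)c(OC)c2)oc2ccccc2c1=O` is reported only as a limit of the assay, > 50000 nM.

The next analogue, compound 4 `CCCC(C)Oc1c(-c2cc(OC)c(OC)c(OC)c2)oc2ccccc2c1=O`, arises through (ethyl in place of hydrogen on a saturated chain carbon, two bonds along the chain from an oxygen on an aromatic ring), which turns isopropyl into 1-methylbutyl. Two kinds of measured step bear on this. Exchanging butyl for isopropyl, a 1.0-fold lower number from compound 1 to compound 3 (0.00 log units; within the scatter), changes nothing beyond the scatter. The longer heptyl chain does matter: an at least 5.6-fold higher number from compound 1 to compound 2 (0.74 log units; beyond the scatter), and in the reverse sense an at least 5.6-fold lower number from compound 2 to compound 3 (0.75 log units; beyond the scatter), both beyond the scatter and both set by the limit. The ethyl added here is smaller than the propyl added in an at least 5.6-fold higher number from compound 1 to compound 2 (0.74 log units; beyond the scatter), so only a modest move toward weaker inhibition is expected, and no drop to the limit. The estimated change is a 1.6-fold higher number from compound 3 to compound 4 (0.20 log units; within the scatter), within the scatter or close to its edge. For compound 4 the expected value in this assay is 14000 nM, with an estimated range of 6000 nM to 40000 nM.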

Compound 4, half-maximal inhibitory concentration: 15100 nM
The estimate for compound 4 lay 1.1-fold (0.03 log units) below the measured number; measured number inside the range.
By their numbers in this assay, from the lowest: compounds 3, 1 and 4 (each within the scatter of the next). At a limit, above all of these: compound 2.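

Working from isopropyl, the ethyl added on the saturated chain carbon gives no change beyond the scatter in this assay: a 1.7-fold higher number from compound 3 to compound 4 (0.23 log units; within the scatter). The methyl that turns butyl into 1-methylbutyl behaves the same way, a 1.7-fold higher number from compound 1 to compound 4 (0.23 log units; within the scatter), so compounds 1, 3 and 4 now form one level group and the ether accepts this branched chain, while replacing heptyl with 1-methylbutyl gives a step beyond the scatter, an at least 3.3-fold lower number from compound 2 to compound 4 (0.51 log units; beyond the scatter). That step has only a lower bound, since the value of compound 2 is a limit of the assay and not a number: the limit of > 50000 nM in this assay, at which 1 of the 4 values shown sits.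

Going by these compounds, whether a straight pentyl or hexyl chain on that oxygen already gives a step beyond the scatter stays open. So does the outcome for an ether chain ending in an amine or a carboxylic acid.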